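This account rests on a few compounds, and the source may have more. Where it says the series, first, only, none or still open, it means among the compounds named here.

Compound 1 `O=C(CCc1cccc2c1B(O)OC2)Nc1cccc(-c2ccccc2)c1`: 220 nM
Compound 2 `O=C(CCc1cccc2c1B(O)OC2)Nc1cccc(-c2ccc(F)cc2)c1`: 250 nM
Compound 3 `O=C(CCc1cccc2c1B(O)OC2)Nc1cccc(-c2ccc(Cl)cc2)c1`: 260 nM

In a functional assay on MDA-MB-231 cells (Homo sapiens) for antiproliferative activity, read by MTT assay, with a stated time of 72 h (on this read-out lower numbers stand for stronger inhibition and higher numbers for weaker inhibition), compound 3 stands level with the other two compounds, with a 1.2-fold higher number from compound 1 to compound 3 (0.07 log units; within the scatter) and a 1.0-fold higher number from compound 2 to compound 3 (0.02 log units; within the scatter). Compound 4 `O=C(CCc1cccc2c1B(O)OC2)Nc1cccc(-c2ccc(OC(F)(F)F)cc2)c1` has trifluoromethoxy in place of chloro on an aromatic carbon, para to a large group (trifluoromethoxy in place of chloro on an aromatic carbon). The nearest evidence is the other halogen change, a 1.1-fold higher number from compound 1 to compound 2 (0.06 log units; within the scatter), together with the two steps above. For the measured compounds named here, none of these steps leaves the scatter, but no measured compound carries trifluoromethoxy, so the expectation is uncertain. No change beyond the scatter is expected in this assay, and no direction is favoured. The expected step is a 1.0-fold higher number from compound 3 to compound 4 (0.02 log units; within the scatter). For compound 4, the estimated value is 270 nM, with an expected range of 120 nM to 600 nM.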

Compound 4, half-maximal inhibitory concentration: 640 nM
Compound 4: the middle estimate sits 2.4-fold (0.37 log units) below what was measured, outside the stated range (above it).
By their numbers in this assay, from the lowest: compounds 1, 2 and 3 (each within the scatter of the next); then compound 4.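

In this assay this position, on an aromatic carbon para to a large group, proves sensitive to what it carries: there is a 2.5-fold higher number from compound 3 to compound 4 (0.39 log units; beyond the scatter) and a 2.6-fold higher number from compound 2 to compound 4 (0.41 log units; beyond the scatter) and a 2.9-fold higher number from compound 1 to compound 4 (0.46 log units; beyond the scatter) in steps that are modest but beyond the scatter. Hydrogen, fluoro and chloro had stayed level here, so trifluoromethoxy is the first group shown to separate from them. Nothing measured here explains this step.

As far as these compounds go, whether a methoxy or a trifluoromethyl group at this place would behave like chloro or like trifluoromethoxy remains open. So does how an amine or a carboxylic acid would fare there.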